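Swapping Pyridin-4-yl for Furan-2-yl on a Weak Inhibitor

The source may hold more compounds than are shown below. What is called first, only, known or untested is meant among the compounds shown, and "the series" means these compounds.

Compound 1 `Oc1ccc(-c2cc(-c3ccncc3)nc(-c3ccc(Cl)cc3)c2)cc1` was tested in an assay on isolated protein for inhibition of DNA topoisomerase 1 (Homo sapiens), with a stated time of 30 min, tested at 100 uM (a lower number here means a weaker effect, a higher number a stronger effect of the compound at the concentration tested), where compound 1 gives 5.9%. Among the two numbers measured, compound 1 stands lowest, and its nearest neighbour is compound 2 `Oc1cccc(-c2cc(-c3ccncc3)nc(-c3ccc(Cl)cc3)c2)c1`, which in this assay gives 8% for compound 2. Among the measured compounds shown here, the only step measured so far, a number 2.1 percentage points higher from compound 1 to compound 2 (within the scatter), concerns the hydroxyphenyl group and lies within the scatter, so the two compounds cannot be told apart on this read-out.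

Compound 3 `Oc1ccc(-c2cc(-c3ccc(Cl)cc3)nc(-c3ccco3)c2)cc1` has not yet been measured. Compared with compound 1 it differs in one place: furan-2-yl in place of pyridin-4-yl on an aromatic carbon. For the measured compounds named here, no measured step touches this position or either of these groups, so the step from compound 1 to compound 2 gives no guidance on its size or direction; it only shows that both measured compounds sit at low inhibition in this assay. With nothing pointing elsewhere, compound 3 is expected to stay in that low range, which means a step of a number 2.1 percentage points higher from compound 1 to compound 3 (within the scatter) that is expected to fall within the scatter. For compound 3 the estimated value in this assay is 8%, with an expected range from 0% to 25%.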

Compound 3, a percentage reported as inhibition, at one concentration (the size of the read-out at that concentration, not a potency): 15.8%
Estimate against measurement, compound 3: 7.8 percentage points below; the measured number falls inside the stated range.
By their numbers in this assay, from the lowest: compounds 1, 2 and 3 (each within the scatter of the next).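

Among the compounds shown here, this position, on an aromatic carbon next to the ring nitrogen, is the first site where a whole ring was exchanged rather than a hydroxyl group moved. The exchange of pyridin-4-yl for furan-2-yl alters the ring size and the hetero atom while leaving the count of hydrogen-bond acceptors unchanged, yet in this assay the step (a number 9.9 percentage points higher from compound 1 to compound 3 (within the scatter)) does not separate the two compounds, so this single change gives no measurable gain or loss on this read-out. No measurement on hand bears on why these two rings give results that cannot be told apart.

The compounds shown leave open whether any group at this position can move the read-out beyond the scatter, for instance a plain phenyl ring with no hetero atom, or a ring carrying an amine or a carboxylic acid. They also leave open whether furan-2-yl would give a comparable number alongside the 3-hydroxyphenyl group of compound 2.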